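The source may report more compounds than this note shows. Statements on the series, on what has been measured and on what is new or still open speak of the compounds shown alone.

Compound 1 `COc1ccc2[nH]cc(-c3nc(C(=O)Nc4cc(OC)c(OC)c(OC)c4)cs3)c2c1` was tested in a functional assay on LNCaP C4-2 cells (Homo sapiens) for cytotoxicity, read by MTT assay, with a stated time of 48 h, in the presence of a further agent that is not named here; on this read-out higher numbers stand for weaker inhibition and lower numbers for stronger inhibition. In this assay compound 1 gives > 100000 nM, which is a limit of the assay rather than a number. Compound 2 `O=C(Nc1ccccc1)c1csc(-c2cn(Cc3ccc(Cl)cc3)c3ccccc23)n1` was examined in the same way. In this assay compound 2 gives > 100000 nM, again a limit. Compound 3 `O=C(NCc1ccccc1)c1csc(-c2c[nH]c3ccccc23)n1` completes the measured set. In this assay compound 3 gives > 100000 nM, also a limit. For the measured compounds named here, compound 1 therefore stands only at the limit of > 100000 nM in this assay, at which 3 of the 3 values shown sit; nothing separates it from the other two measured compounds, and no step between measured compounds can be read from these results.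

Compound 4 `COc1cc(NC(=O)c2csc(-c3c[nH]c4ccc(F)cc34)n2)cc(OC)c1OC` has not yet been measured. It differs from compound 1 in one place: fluoro in place of methoxy on an aromatic carbon. Going by the values given here, with every measured value sitting at the limit, there is no measured step from which a direction could be drawn, and nothing within these data suggests that the change should move the result beyond the usual scatter. The step is therefore expected to be no change beyond that scatter, a number no higher from compound 1 to compound 4 (the limit leaves the size open). Compound 4 is estimated to give 100000 nM in this assay, within a range from 30000 nM to 300000 nM, and most probably the result will again be reported as a limit.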

Compound 4, half-maximal inhibitory concentration: > 100000 nM
Compound 4 was reported as a limit (the forecaster's own chance of this, stated with the estimate: 80%); the middle value lies on the limit itself.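

No step can be read from compound 1 to compound 4, because both results are limits of the assay and not numbers: the limit of > 100000 nM in this assay, at which 4 of the 4 values shown sit.

The compounds shown leave open whether any of them gives a measurable value in this assay and how fluoro and methoxy truly compare.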